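The compounds below may be only part of what the source reports. "The series", "measured", "known", "first", "only" and "open" are said of these compounds alone.

Compound 1 `O=C(c1ccn2c1CSC2c1cccnc1)c1c[nH]c2cc(-c3ccc(F)cc3)ccc12` is measured in a functional assay (Oryctolagus cuniculus) for antagonist activity at platelet-activating factor receptor (Cavia porcellus) (a higher number here means a weaker inhibitor, a lower number a stronger inhibitor), at 75 nM. It stands second highest of the three numbers: compound 2 `CN(C)C(=O)n1cc(C(=O)c2ccn3c2CSC3c2cccnc2)c2ccccc21` gives 95 nM, within the scatter of compound 1, while compound 3 `CN(C)C(=O)n1cc(C(=O)c2ccn3c2CSC3c2cccnc2)c2ccc(Cc3ccccc3)cc21` gives 13 nM, the lowest number of the set. Among the measured compounds shown here, the one single-point step available, a 7.3-fold lower number from compound 2 to compound 3 (0.86 log units; beyond the scatter), concerns a benzyl added on an aromatic carbon and does not touch the position changed here. Compound 4 `NCCn1cc(C(=O)c2ccn3c2CSC3c2cccnc2)c2ccc(-c3ccc(F)cc3)cc21` differs from compound 1 by 2-aminoethyl in place of hydrogen on an aromatic nitrogen. For the measured compounds named here, no measured pair isolates a change on that aromatic nitrogen; compounds 2 and 3 carry a different group there than compound 1 but also differ elsewhere, so their values with compound 1 show only that a group on this nitrogen is compatible with numbers in the same range. Compound 4 is therefore expected to show a 1.3-fold lower number from compound 1 to compound 4 (0.10 log units; within the scatter), a step no larger than the scatter. The estimated value of compound 4 in this assay is 60 nM, within the range 20 nM to 200 nM.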

Compound 4, inhibition constant: 38 nM
Beside the measured number, compound 4's estimate is 1.6-fold (0.20 log units) above it; low and high end bracket the measured number.
By their numbers in this assay, from the lowest: compound 3; then compounds 4, 1 and 2 (each within the scatter of the next, the first and the last beyond it).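

Among the compounds shown here, replacing hydrogen with 2-aminoethyl on the aromatic nitrogen gives a 2.0-fold lower number from compound 1 to compound 4 (0.30 log units; within the scatter) in this assay and is the first pair to isolate this position. For the compounds shown here, on the core of compound 1, this nitrogen therefore carries a 2-aminoethyl chain with no step beyond the scatter, and the hydrogen on it is not needed for a number in this range, whereas the earlier compounds showed a group there only together with differences elsewhere. Nothing given here accounts for this result. Whether the amine of the chain counts for anything stays open, since a plain ethyl group, a longer aminoalkyl chain and a chain ending in a carboxylic acid are not among the compounds shown. As far as these compounds go, how the dimethylcarbamoyl group would compare with 2-aminoethyl on the core of compound 1 also stays open.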